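This account rests on a few compounds, and the source may have more. Where it says the series, first, only, none or still open, it means among the compounds named here.

In an ADME assay on a cell-free system (plasma, Mus musculus) for metabolic stability, read by LC-MS, tested at 2 uM (on this read-out higher numbers stand for a longer-lived compound and lower numbers for a shorter-lived compound), compound 1 `CC(=O)N1CCC(c2ccc3c(c2)oc(=O)n3C(=O)NCCCCc2ccccc2)CC1` gives 0.5 h, and compound 2 `CN1CCC(c2ccc3c(c2)oc(=O)n3C(=O)NCCCCc2ccccc2)CC1=O` gives 0.6 h. These two values cannot be told apart: the measured change is a 1.2-fold higher number from compound 1 to compound 2 (0.08 log units; within the scatter). Compound 2 therefore stands level with compound 1. Compound 3 `CN1CCN(c2ccc3c(c2)oc(=O)n3C(=O)NCCCCc2ccccc2)C(=O)C1` has 4-methyl-2-oxopiperazin-1-yl in place of 1-methyl-2-oxopiperidin-4-yl on an aromatic carbon. Within the data shown here, only one measured step bears on this change, the swap on an aromatic carbon that links compound 1 and compound 2, and it stayed within the scatter. Among the measured compounds shown here, no measured compound carries the new group, so this single step is a thin guide. Even so, no shift beyond the scatter is expected in this assay. The expected change is no change at the digits printed from compound 2 to compound 3 (within the scatter). For compound 3 the estimated half-life is 0.6 h, with an expected range from 0.3 h to 1.2 h.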

Compound 3, half-life: 0.333 h
The estimate for compound 3 lay 1.8-fold (0.26 log units) above the measured number; the measured number falls inside the stated range.
By their numbers in this assay, from the lowest: compounds 3, 1 and 2 (each within the scatter of the next).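

Swapping 1-methyl-2-oxopiperidin-4-yl for 4-methyl-2-oxopiperazin-1-yl on the aromatic carbon gives a 1.8-fold lower number from compound 2 to compound 3 (0.26 log units; within the scatter) in this assay, and swapping 1-acetylpiperidin-4-yl for the same group gives a 1.5-fold lower number from compound 1 to compound 3 (0.18 log units; within the scatter). This position has now carried three different six-membered non-aromatic rings, one of them with 2 hetero atoms, and compound 1, compound 2 and compound 3 all lie within the scatter of one another, so a second hetero atom in the ring shows no measurable effect on half-life here. No supporting measurement is available to explain this result.

The compounds shown leave open whether a group of a different kind at this position, such as a free amine or a carboxylic acid on a short chain, would move the half-life beyond the scatter. They also leave open whether the same swaps would read alike on a different core.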